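Aminoquinone series: chain terminus swap at compound 4

The source may hold more compounds than are shown below. What is called first, only, known or untested is meant among the compounds shown, and "the series" means these compounds.

Measured compounds in a functional assay on SNB-19 cells (Homo sapiens) for antiproliferative activity, read by MTT assay; on this read-out higher numbers stand for weaker inhibition and lower numbers for stronger inhibition:
compound 1, `CNC1=CC(=O)c2ccccc2C1=O`: 114000 nM
compound 2, `O=C1C=C(N2CCCC2)C(=O)c2ccccc21`: > 200000 nM
compound 3, `O=C1C=C(NCCO)C(=O)c2ccccc21`: 108000 nM

The value of compound 2 in this assay is a limit, not a number, (the limit of > 200000 nM in this assay, at which 1 of the 3 values shown sits). Compound 3 and compound 1 sit within the scatter of each other, as the step of a 1.1-fold lower number from compound 1 to compound 3 (0.02 log units; within the scatter) shows; the steps of an at least 1.7-fold higher number from compound 1 to compound 2 (0.24 log units; that floor lies within the scatter) and an at least 1.8-fold lower number from compound 2 to compound 3 (0.26 log units; that floor lies within the scatter) have floors that also lie within the scatter. No measured change in this set moves this assay beyond the scatter.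

Compound 4, `NCCCNC1=CC(=O)c2ccccc2C1=O`, differs from compound 3 by aminomethyl in place of hydroxy on a saturated chain carbon, two bonds along the chain from an amine nitrogen. Among the compounds with values here, the nearest measured step is the chain extension from compound 1 to compound 3, a 1.1-fold lower number from compound 1 to compound 3 (0.02 log units; within the scatter), which was flat; no measured step probes an amine at the chain end. The expectation is therefore no step beyond the scatter in this assay, the step from compound 3 to compound 4 being estimated as a 1.2-fold lower number from compound 3 to compound 4 (0.08 log units; within the scatter). Compound 4 is expected to give about 90000 nM in this assay, within the range 30000 nM to 250000 nM.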

Compound 4, half-maximal inhibitory concentration: 71300 nM
The estimate for compound 4 lay 1.3-fold (0.10 log units) above the measured number; the measured number falls inside the stated range.
By their numbers in this assay, from the lowest: compounds 4, 3 and 1 (each within the scatter of the next). At a limit, above all of these: compound 2.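

In this assay, aminomethyl in place of hydroxy on a saturated chain carbon, two bonds along the chain from an amine nitrogen, stays within the scatter (a 1.5-fold lower number from compound 3 to compound 4 (0.18 log units; within the scatter)), and the comparison with the methylamino compound does too (a 1.6-fold lower number from compound 1 to compound 4 (0.20 log units; within the scatter)), so in this set an amine at the chain end does not separate from a hydroxy end or from the methyl group. Within the data shown here, the only step in the set beyond the scatter is (3-aminopropyl)amino in place of pyrrolidin-1-yl (an at least 2.8-fold lower number from compound 2 to compound 4 (0.44 log units; beyond the scatter)). That step gives a floor and not a size, as compound 2 is held at a limit: the limit of > 200000 nM in this assay, at which 1 of the 4 values shown sits.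

On these data alone, whether a longer chain, a dimethylamino end or a carboxylic acid at the chain end would move the number beyond the scatter stays open. As far as these compounds go, the true distance from compound 2 also stays open.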